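Amino in Place of Nitro on Two Related Cores

A few compounds are considered here, and "the series" means these few. Any claim that something is new, unique, unknown or untested is made for them only; others in the source may bear on it.

Compound 1 `COc1ccc(OC(=O)c2cc(OC)c(OC)c(OC)c2)cc1[N+](=O)[O-]` and compound 2 `COc1ccc(OC(=O)c2cc(OC)c(OC)c(OC)c2)cc1N` share one core, and compound 2 carries the change (amino in place of nitro on an aromatic carbon). In a functional assay on HT-29 cells (Homo sapiens) for antiproliferative activity, read by MTT assay, with a stated time of 72 h (a lower number here means a stronger inhibitor, a higher number a weaker inhibitor), compound 1 reaches only the limit of the assay, > 100000 nM. Compound 2 likewise gives only the limit, > 100000 nM. The step that the two limits leave unreadable from compound 1 to compound 2 is therefore unreadable, as shown by the limit of > 100000 nM in this assay, at which 3 of the 3 values shown sit. Compound 3 `COc1ccc(C(=O)Oc2cc(OC)c(OC)c(OC)c2)cc1[N+](=O)[O-]` has the same atoms as compound 1 joined differently; the difference between the two cores is not broken down here. In this assay compound 3 also gives only the limit, > 100000 nM. Compound 4 `COc1ccc(C(=O)Oc2cc(OC)c(OC)c(OC)c2)cc1N` differs from compound 3 by amino in place of nitro on an aromatic carbon, the same change in the same surroundings. Compound 2 stayed at > 100000 nM after this change. Compound 4 is therefore expected to remain at the limit as well, with a step that the limit leaves unreadable from compound 3 to compound 4 as the expected step. The estimate for compound 4 is 150000 nM.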

Compound 4, half-maximal inhibitory concentration: > 100000 nM
Compound 4: only a limit was reported; the forecaster's own chance of this, stated with the estimate: 85%; the middle value does not contradict the limit.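

In this assay, among these compounds, compound 4 gives only the limit > 100000 nM and no step from compound 3 to compound 4 can be read. The compounds shown leave open what amino in place of nitro does to activity on either core, and how the two cores compare.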